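Ester to free acid on a styryl sulfone cytotoxic scaffold

A few compounds are considered here, and "the series" means these few. Any claim that something is new, unique, unknown or untested is made for them only; others in the source may bear on it.

Of the compounds shown here, two have been tested so far in a functional assay on K562 cells (Homo sapiens) for cytotoxicity, read by trypan blue exclusion, with a stated time of 96 h; on this read-out higher numbers stand for weaker inhibition and lower numbers for stronger inhibition. Compound 1 `COc1cc(OC)c(/C=C/S(=O)(=O)Cc2ccc(Cl)cc2N)c(OC)c1` gives 2500 nM. Compound 2 `COC(=O)[C@H](C)Nc1cc(CS(=O)(=O)/C=C/c2c(OC)cc(OC)cc2OC)ccc1OC` gives 200 nM, the lower of the two numbers, and the gap between compound 2 and compound 1 lies well beyond the usual scatter. Compound 3 `COc1cc(OC)c(/C=C/S(=O)(=O)Cc2ccc(OC)c(N[C@@H](C)C(=O)O)c2)c(OC)c1` has not yet been measured in this assay. Compared with compound 2, compound 3 carries the change (hydrogen in place of methyl on an oxygen next to a carbonyl group), so the methoxycarbonyl of compound 2 becomes a carboxy group in compound 3, while the rest of the shared core is unchanged. For the measured compounds named here, no measured pair in this set shows the effect of this particular change, so the expectation rests on compound 2 alone. The step in this assay is expected to be small, most likely a modest move to a higher number, a 2.0-fold higher number from compound 2 to compound 3 (0.30 log units; within the scatter), but a result within the scatter of compound 2 would not be surprising. Compound 3 is therefore estimated at 400 nM, within a range from 100 nM to 2000 nM.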

Compound 3, half-maximal inhibitory concentration: 15 nM
Beside the measured number, compound 3's estimate is 27-fold (1.43 log units) above it; the whole stated range lies above it.
By their numbers in this assay, from the lowest: compound 3; then compound 2; then compound 1.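

In this assay, putting hydrogen in place of methyl on an oxygen next to a carbonyl group, which turns methoxycarbonyl into carboxy, gives a 13-fold lower number from compound 2 to compound 3 (1.12 log units; beyond the scatter). This shows that the end of the 1-carboxyethyl chain is far from a silent spot on the molecule: losing a single methyl, just 1 heavy atom, moves the number well beyond the scatter, and it moves towards stronger inhibition. Within this pair, the free carboxy form rather than the methyl ester carries the lower number, something that compound 2 on its own could not reveal, and nothing available here explains the size of the step.

This single pair cannot tell whether the gain belongs to the carboxylic acid specifically or would also appear with another group at this spot, such as a primary amide, a tetrazole or a hydroxymethyl group. It also leaves open whether the same swap from ester to acid would give a step of similar size with a longer chain, or with the opposite configuration at the chain's stereocentre.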